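The source may hold more compounds than are shown below. What is called first, only, known or untested is meant among the compounds shown, and "the series" means these compounds.

Measured compounds in a functional assay on 143B cells (Homo sapiens) for antiproliferative activity, read by MTT assay, with a stated time of 48 h; on this read-out lower numbers stand for stronger inhibition and higher numbers for weaker inhibition:
compound 1 `O=C(/C=C/c1cccc(NC(=O)c2ccccc2Br)c1)c1nc2ccccc2[nH]1` gives 6050 nM
compound 2 `Cc1cccc(C(=O)Nc2cccc(/C=C/C(=O)c3nc4ccccc4[nH]3)c2)c1` gives 4880 nM
compound 3 `COc1ccc(C(=O)Nc2cccc(/C=C/C(=O)c3nc4ccccc4[nH]3)c2)cc1` gives 6330 nM

Compound 3 holds the highest of the three numbers, though the two steps that end at it, a 1.0-fold higher number from compound 1 to compound 3 (0.02 log units; within the scatter) and a 1.3-fold higher number from compound 2 to compound 3 (0.11 log units; within the scatter), both lie within the scatter, as does a 1.2-fold lower number from compound 1 to compound 2 (0.09 log units; within the scatter); the three amide variants are not separable on this read-out.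

Compound 4 `O=C(/C=C/c1cccc(NS(=O)(=O)c2ccc(Cl)cc2)c1)c1nc2ccccc2[nH]1` differs from compound 3 in one place: (4-chlorophenyl)sulfonyl in place of (4-methoxyphenyl)carbonyl on a nitrogen on an aromatic ring. Among the measured compounds shown here, no measured step swaps a carbonyl for a sulfonyl on that nitrogen, so nothing bears directly on it; the three steps across the aryl amides were all within scatter. The expected step is therefore none beyond the scatter, and compound 4 is estimated at 6000 nM (range 2500 nM to 15000 nM), a change of a 1.1-fold lower number from compound 3 to compound 4 (0.02 log units; within the scatter).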

Compound 4, half-maximal inhibitory concentration: 7450 nM
Estimate against measurement, compound 4: 1.2-fold (0.09 log units) below; measured number inside the range.
By their numbers in this assay, from the lowest: compounds 2, 1, 3 and 4 (each within the scatter of the next).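

On this assay the nitrogen on an aromatic ring accepts a sulfonyl linkage as well as a carbonyl one with no separable change: a 1.2-fold higher number from compound 3 to compound 4 (0.07 log units; within the scatter) and a 1.5-fold higher number from compound 2 to compound 4 (0.18 log units; within the scatter) and a 1.2-fold higher number from compound 1 to compound 4 (0.09 log units; within the scatter) all lie within the scatter. Among the compounds shown here, the earlier compounds changed only the aryl group on a carbonyl, so this is the first sign that the linking group itself can change at this position, although the ring substituent changes in the same step. No measured evidence accounts for this outcome.

Still open, on these data alone, is whether any group on this nitrogen moves the number beyond the scatter, such as methylsulfonyl or a longer alkyl chain on a carbonyl. A free amine at this position is equally untested here.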